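Replacing 1H-pyrazol-3-yl with piperidin-1-yl: working notes

This account rests on a few compounds, and the source may have more. Where it says the series, first, only, none or still open, it means among the compounds named here.

In a functional assay on MCF7 cells (Homo sapiens) for antiproliferative activity, read by CellTiter-Glo, with a stated time of 5 days (on this read-out lower numbers stand for stronger inhibition and higher numbers for weaker inhibition), compound 1 (`CC/C(=C(/c1ccc(/C=C/C(=O)O)cc1)c1ccc2c(cnn2C)c1)c1ccccc1`) gives 300 nM and compound 2 (`CC/C(=C(/c1ccc(/C=C/C(=O)O)cc1)c1ccc2ccccc2c1)c1ccccc1`) gives 180 nM in the same read-out. Compound 3 (`CC/C(=C(/c1ccc(/C=C/C(=O)O)cc1)c1ccc(-c2cc[nH]n2)cc1)c1ccccc1`) gives 440 nM as its number, within the scatter of compound 1 and beyond it from compound 2. Compound 4 (`CC/C(=C(/c1ccc(/C=C/C(=O)O)cc1)c1ccc(N2CCCCC2)cc1)c1ccccc1`) carries piperidin-1-yl in place of 1H-pyrazol-3-yl on an aromatic carbon. For the measured compounds named here, the only measured step (a 1.7-fold lower number from compound 1 to compound 2 (0.22 log units; within the scatter)) stays within the scatter and exchanges other groups, so it bears only loosely on this change. No step beyond the scatter is therefore expected in this assay for this replacement. The expected step is small (a 1.4-fold lower number from compound 3 to compound 4 (0.14 log units; within the scatter)). For compound 4 the estimate is 320 nM with an expected range from 110 nM to 900 nM in this read-out.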

Compound 4, half-maximal inhibitory concentration: 450 nM
For compound 4 the middle estimate is 1.4-fold (0.15 log units) below the measured one; low and high end bracket the measured number.
By their numbers in this assay, from the lowest: compounds 2, 1, 3 and 4 (each within the scatter of the next, the first and the last beyond it).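

For the compounds shown here, on the position para to a large group, the first measured exchange of an aromatic ring with 1 hydrogen-bond donor for a non-aromatic ring with 0 hydrogen-bond donors stays within the scatter in this assay (a 1.0-fold higher number from compound 3 to compound 4 (0.01 log units; within the scatter)). At this position, neither the ring type nor the donor count separates compound 3 from compound 4 in this read-out. No measurement offered here gives a reason for this result.

Going by these compounds, whether a morpholin-4-yl, a dimethylamino or a carboxylic acid group at this position would also stay within the scatter of compound 3 remains open.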